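The source may hold more compounds than are shown below. What is called first, only, known or untested is meant among the compounds shown, and "the series" means these compounds.

Compound 2 `O=C(NCC1CCC(F)(F)CC1)c1c(Cl)ccc2ncccc12` gives 230 nM in an assay on HEK293 cells for antagonist activity at P2X purinoceptor 7 (Homo sapiens), read by fluorescence, with stated times of 20 min and 30 min; on this read-out higher numbers stand for weaker inhibition and lower numbers for stronger inhibition; compound 1 `COCCNc1ccc2c(C(=O)NCC3CCC(F)(F)CC3)c(Cl)ccc2n1` gives 89 nM in this assay.

Compound 2 holds the higher of the two numbers. Within the data shown here, the only known step, a 2.6-fold higher number from compound 1 to compound 2 (0.41 log units; beyond the scatter), is modest and beyond the scatter. Compound 3 `O=C(NCC1CCC(F)(F)CC1)c1c(Cl)ccc2nc(C3=CCCC3)ccc12` differs from compound 2 by cyclopent-1-en-1-yl in place of hydrogen on an aromatic carbon, on the aromatic carbon next to the ring nitrogen, the same place where compound 1 carries its (2-methoxyethyl)amino group. That one step suggests a substituent there can lower the number, but a ring of five carbons is a different kind of group, so only a small expected move is assumed: a 1.9-fold lower number from compound 2 to compound 3 (0.28 log units; within the scatter). Compound 3 is therefore estimated at 120 nM, expected between 40 nM and 350 nM.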

Compound 3, half-maximal inhibitory concentration: 36 nM
For compound 3 the middle estimate is 3.3-fold (0.52 log units) above the measured one, and the stated range ends above it.
By their numbers in this assay, from the lowest: compound 3; then compound 1; then compound 2.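

In this assay, the aromatic carbon next to the ring nitrogen accepts a group of carbon only, and cyclopent-1-en-1-yl in place of hydrogen gives a 6.4-fold lower number from compound 2 to compound 3 (0.81 log units; beyond the scatter). Exchanging (2-methoxyethyl)amino for the same ring gives a 2.5-fold lower number from compound 1 to compound 3 (0.39 log units; beyond the scatter), so among these compounds the lower number does not depend on an amino group at this position. Nothing at hand explains these steps. The compounds shown leave open how a saturated cyclopentyl, a phenyl or a plain methyl group would read at this position, and so whether the double bond or the ring itself goes with the lower number.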